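The source may report more compounds than this note shows. Statements on the series, on what has been measured and on what is new or still open speak of the compounds shown alone.

Working notes on the series, read in a functional assay on U-87MG ATCC cells (Homo sapiens) for inhibition, read by sulforhodamine B assay; on this read-out higher numbers stand for weaker inhibition and lower numbers for stronger inhibition. Compound 3 `NC(c1ccccc1)C1CCN(c2ncnc3[nH]ccc23)CC1` has no number to start from: its entry in this assay reads "not determined" (no result reported) and no result was reported, so its place in the series is open. The nearest reference points are two other compounds bearing the 4-chlorophenyl group. Compound 1 `NCC1(Cc2ccc(Cl)cc2)CCN(c2ncnc3[nH]ccc23)CC1` gives 4300 nM in this read-out, and compound 2 `NC(c1ccc(Cl)cc1)C1CCN(c2ccnc3[nH]ccc23)CC1` gives 3500 nM in the same read-out. These two values lie within the usual scatter of each other.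

Going from compound 3 to compound 4 `NC(c1ccc(Cl)cc1)C1CCN(c2ncnc3[nH]ccc23)CC1` the change is chloro in place of hydrogen on an aromatic carbon in all: chloro in place of hydrogen on an aromatic carbon, para to a large group, which turns phenyl to 4-chlorophenyl. Among the measured compounds shown here, no measured pair shows this change, and the size of the step cannot be read from the data. No step beyond the scatter is expected from it in this assay, and no direction can be argued. The expectation for compound 4 therefore rests on compound 1 at 4300 nM and compound 2 at 3500 nM as neighbours carrying the same group.

In this assay the estimated value for compound 4 is 3500 nM with an expected range from 1500 nM to 8000 nM as its limits.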

Compound 4, half-maximal inhibitory concentration: 6000 nM
Beside the measured number, compound 4's estimate is 1.7-fold (0.23 log units) below it; the range from low to high includes it.
By their numbers in this assay, from the lowest: compounds 2, 1 and 4 (each within the scatter of the next).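

Among the compounds shown here, compound 3 has no result in this assay, so no step from it to compound 4, which gives 6000 nM, can be read. The compounds shown leave open how phenyl to 4-chlorophenyl shifts this read-out, in size or direction. No independent evidence bears on this result.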